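Amide to Ketone at the Carbonyl: What Compound 4 Should Show

The source may report more compounds than this note shows. Statements on the series, on what has been measured and on what is new or still open speak of the compounds shown alone.

Measured so far in an assay on isolated protein with malate dehydrogenase, mitochondrial (Sus scrofa) as the target; a lower number here means a stronger inhibitor, a higher number a weaker inhibitor:
compound 1, `O=C(O)c1cnc2cc(S(=O)(=O)O)ccc2c1O`, gives 2140000 nM
compound 2, `O=C(O)c1ccc2c(O)c(C(=O)O)cnc2c1`, gives 1070000 nM
compound 3, `NC(=O)c1ccc2c(O)c(C(=O)O)cnc2c1`, gives 741000 nM

Among these three, compound 3 carries the lowest number, but the step of a 1.4-fold lower number from compound 2 to compound 3 (0.16 log units; within the scatter) lies within the scatter, so those two cannot be ordered; only compound 1 stands apart, by a 2.9-fold lower number from compound 1 to compound 3 (0.46 log units; beyond the scatter). The unmeasured compound 4, `CC(=O)c1ccc2c(O)c(C(=O)O)cnc2c1`, differs from compound 3 in one place: methyl in place of amino on a carbonyl carbon.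

All three measured steps touch the same region: the group on that aromatic carbon, or the carbonyl attached to it. a 2.0-fold lower number from compound 1 to compound 2 (0.30 log units; within the scatter) and a 1.4-fold lower number from compound 2 to compound 3 (0.16 log units; within the scatter) both lie within the scatter, and even a 2.9-fold lower number from compound 1 to compound 3 (0.46 log units; beyond the scatter) is modest. Changes here have moved the number little so far. Within the data shown here, no measured pair exchanges amino for methyl on a carbonyl carbon, so the direction of this particular exchange is not known from the data. In this assay compound 4 is therefore expected to show a step no larger than the scatter, a 1.2-fold higher number from compound 3 to compound 4 (0.08 log units; within the scatter). Compound 4 is estimated at 900000 nM, with a range from 400000 nM to 2000000 nM.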

Compound 4, half-maximal inhibitory concentration: 912000 nM
Estimate against measurement, compound 4: 1.0-fold (0.01 log units) below; the range from low to high includes it.
By their numbers in this assay, from the lowest: compounds 3, 4, 2 and 1 (each within the scatter of the next, the first and the last beyond it).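

In this assay, the change from carbamoyl to acetyl takes away the hydrogen-bond donor counted on the amino group, yet a 1.2-fold higher number from compound 3 to compound 4 (0.09 log units; within the scatter) leaves the two compounds unresolved, so that donor shows no measurable effect at this carbonyl carbon. The exchange of hydroxy for methyl on the same carbon, a 1.2-fold lower number from compound 2 to compound 4 (0.07 log units; within the scatter), is likewise unresolved, so the carboxy, carbamoyl and acetyl groups cannot be ordered here, while the sulfo group is separated only modestly, as in a 2.3-fold lower number from compound 1 to compound 4 (0.37 log units; beyond the scatter), and compound 2 goes against even that separation, since its step from compound 1 stays within the scatter. No independent data are available to explain these steps.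

What the compounds shown leave open is whether this flat response holds for groups of another kind on that aromatic carbon, such as a plain amine, an ester or a longer acyl chain like propanoyl. Going by these compounds, all four compounds also keep the same carboxylic acid and hydroxy group on the shared core, so what those two groups contribute to the values in this assay remains unknown.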